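This account rests on a few compounds, and the source may have more. Where it says the series, first, only, none or still open, it means among the compounds named here.

Compound 1 `CCCc1nc(-c2ccccc2)c(CNCCN2CCN(c3ccccc3Cl)CC2)o1` and compound 2 `CCCc1nc(-c2ccccc2)c(CNCCCN2CCN(c3ccc(F)cc3)CC2)o1` share a common core. In an assay on HEK293 cells for inhibition of Voltage-dependent T-type calcium channel subunit alpha-1G (Homo sapiens), read by patch clamp (on this read-out higher numbers stand for weaker inhibition and lower numbers for stronger inhibition), compound 1 gives 4370 nM. In this assay compound 2 gives 3210 nM, a number that does not differ from that of compound 1 beyond the scatter, so neither can be called the stronger. Compound 3 `CCCc1nc(-c2ccccc2)c(CNCCCN2CCN(c3cccc(Cl)c3)CC2)o1` follows from compound 2 by 3-chlorophenyl in place of 4-fluorophenyl on an amine nitrogen in a ring. Among the compounds with values here, no measured pair shows a comparable change, so no shift beyond the scatter is expected for the step of a 1.0-fold lower number from compound 2 to compound 3 (0.00 log units; within the scatter). Compound 3 is therefore estimated at 3200 nM in this assay, with a range from 1200 nM to 8500 nM.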

Compound 3, half-maximal inhibitory concentration: 1750 nM
Beside the measured number, compound 3's estimate is 1.8-fold (0.26 log units) above it, and the stated range covers the measured number.
By their numbers in this assay, from the lowest: compounds 3, 2 and 1 (each within the scatter of the next, the first and the last beyond it).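

With 3-chlorophenyl in place of 4-fluorophenyl on the amine nitrogen in the ring, this assay shows a 1.8-fold lower number from compound 2 to compound 3 (0.26 log units; within the scatter). This first step at this position therefore shows that exchanging these two groups, which have the same heavy-atom count, does not separate the compounds beyond the scatter. Nothing measured here bears on the result.

The compounds shown leave open how this read-out would respond to an amine or a carboxylic acid on the phenyl ring at this position. They also leave open the effect of a longer chain to the ring nitrogen.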